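Replacing trifluoromethyl with fluoro in compound 2

The compounds below may be only part of what the source reports. "The series", "measured", "known", "first", "only" and "open" are said of these compounds alone.

Compound 1 `O=S1(=O)C=Cc2ccc(Nc3ccc(F)c(F)c3)cc21` gives 1550 nM
Compound 2 `O=S1(=O)C=Cc2cccc(Nc3cccc(C(F)(F)F)c3)c21` gives 360 nM
Compound 3 `O=S1(=O)C=Cc2cccc(Nc3c(F)c(F)c(F)c(F)c3F)c21` gives 3480 nM

In a functional assay on A549 cells (Homo sapiens) for antiproliferative activity, read by MTT assay, with a stated time of 72 h (a lower number here means a stronger inhibitor, a higher number a weaker inhibitor), compound 2 has the lowest number of the three (360 nM), and its gaps to both others lie beyond the scatter. Compound 4 `O=S1(=O)C=Cc2cccc(Nc3cccc(F)c3)c21` differs from compound 2 in one place (fluoro in place of trifluoromethyl on an aromatic carbon): fluoro in place of trifluoromethyl on an aromatic carbon, meta to a large group. Going by the values given here, no measured pair shows this change alone, so the expectation rests on thin evidence. Compound 3 also has fluoro and no trifluoromethyl, and it gives a higher number (3480 nM). A weaker result is therefore expected, with the expected step of a 2.5-fold higher number from compound 2 to compound 4 (0.40 log units; beyond the scatter) going upward, beyond the scatter. Compound 4 is estimated at 900 nM (expected range 320 nM to 2500 nM).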

Compound 4, half-maximal inhibitory concentration: 2550 nM
For compound 4 the middle estimate is 2.8-fold (0.45 log units) below the measured one; measured number outside the range, above it.
By their numbers in this assay, from the lowest: compound 2; then compounds 1, 4 and 3 (each within the scatter of the next, the first and the last beyond it).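

In this assay, changing trifluoromethyl to fluoro on this aromatic carbon gives a 7.1-fold higher number from compound 2 to compound 4 (0.85 log units; beyond the scatter), a step beyond the scatter. Going by these compounds alone, this is the first comparison in which only this group changes, and it shows that trifluoromethyl at this place goes with the lower number, while fluoro does not match it. Nothing measured here explains the step.

Still open, as far as these compounds go, is whether a methyl group, a chlorine atom or a methoxy group at this place would give a number close to that of compound 2, or whether trifluoromethyl stands alone.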